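A few compounds are considered here, and "the series" means these few. Any claim that something is new, unique, unknown or untested is made for them only; others in the source may bear on it.

Measured in a physicochemical assay for lipophilicity, using the shake flask method; a higher number here means a more lipophilic compound, a lower number a more polar compound:
- compound 1 `CCOC(=O)CO/N=C/c1c(N)ncnc1Oc1ccc(NC(=O)C2(C(=O)Nc3ccc(F)cc3)CC2)cc1F`: 3.15
- compound 2 `Nc1ncnc(Oc2ccc(NC(=O)C3(C(=O)Nc4ccc(F)cc4)CC3)cc2F)c1/C=N/OCC(=O)N1CCOCC1`: 2.1

Compound 2, at 2.1, is the lower of the two. Compound 3 `COCCCO/N=C/c1c(N)ncnc1Oc1ccc(NC(=O)C2(C(=O)Nc3ccc(F)cc3)CC2)cc1F` carries 2-methoxyethyl in place of (morpholin-4-yl)carbonyl on a saturated chain carbon bound to an oxygen. Among the measured compounds shown here, one measured step bears on this: a number 1.05 log units lower from compound 1 to compound 2 (beyond the scatter), a large one, with morpholin-4-yl in place of ethoxy on a carbonyl carbon. For the measured compounds named here, compound 3 has no morpholin-4-yl either, so a similarly large rise in this assay is expected, and no measured compound shows this chain. The expected change is a number 1.10 log units higher from compound 2 to compound 3 (beyond the scatter). For compound 3 the estimated value is 3.2, with an expected range of 2.7 to 3.7.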

Compound 3, partition coefficient: 3.18
Compound 3: middle estimate off by 0.02 log units, on the high side; low and high end bracket the measured number.
By their numbers in this assay, from the lowest: compound 2; then compounds 1 and 3 (each within the scatter of the next).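

In this assay the change to 2-methoxyethyl gives a number 1.08 log units higher from compound 2 to compound 3 (beyond the scatter) and the comparison with the ester gives a number 0.03 log units higher from compound 1 to compound 3 (within the scatter) so a chain without a carbonyl cannot be told apart from the ethoxycarbonyl chain at this place. Among these compounds, only compound 2, with morpholin-4-yl, stands apart from the other two. Nothing available explains this result. Still open, going by these compounds, is whether a tertiary amine or a carboxylic acid on this chain would give a number as low as that of compound 2. On these data alone, a longer chain ending in methoxy is equally open.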